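Methyl to Fluorine on the Benzyl Group

This account rests on a few compounds, and the source may have more. Where it says the series, first, only, none or still open, it means among the compounds named here.

Compound 1 `Clc1ccccc1CSc1nnc(-c2ccc3c(c2)OCCO3)n1-c1ccccc1`: 17400 nM
Compound 2 `Cc1ccccc1CSc1nnc(-c2ccc3c(c2)OCCO3)n1-c1ccccc1`: > 100000 nM (a limit, not a number)

Both entries come from a functional assay on BGC-823 cells (Homo sapiens) for antiproliferative activity, read by MTT assay, with a stated time of 24 h; a higher number here means a weaker inhibitor, a lower number a stronger inhibitor. Compound 2 has no number of its own, only (the limit of > 100000 nM in this assay, at which 1 of the 2 values shown sits). The next structure is compound 3 `Fc1cccc(F)c1CSc1nnc(-c2ccc3c(c2)OCCO3)n1-c1ccccc1`, which carries 2,6-difluorophenyl in place of 2-methylphenyl on a saturated chain carbon bound to a sulfur.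

Among the compounds with values here, one measured step bears on this change. Methyl in place of chloro on an aromatic carbon gave an at least 5.7-fold higher number from compound 1 to compound 2 (0.75 log units; beyond the scatter). Compound 3 also loses the methyl, so a move towards a lower number in this assay is expected, though not necessarily as far as compound 1 at 17400 nM. With a single step as a guide, this expectation is loose. The expected change is an at least 2.5-fold lower number from compound 2 to compound 3 (0.39 log units; beyond the scatter). The estimate for compound 3 is 40000 nM, with an expected range from 12000 nM to 100000 nM.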

Compound 3, half-maximal inhibitory concentration: 84200 nM
Compound 3: the middle estimate sits 2.1-fold (0.32 log units) below what was measured, within the range that was stated.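

In this assay, losing the methyl is not enough to reach the level of the 2-chlorophenyl group: the change to 2,6-difluorophenyl gives a 4.8-fold higher number from compound 1 to compound 3 (0.68 log units; beyond the scatter). Set against 2-methylphenyl, the same group gives an at least 1.1-fold lower number from compound 2 to compound 3 (0.07 log units; that floor lies within the scatter), so no gain over the methyl group can be claimed. Compound 2 holds only a limit, which leaves that step with a floor and no true size: the limit of > 100000 nM in this assay, at which 1 of the 3 values shown sits.

The gap between 2-chlorophenyl and 2,6-difluorophenyl could lie in the kind of halogen or in the number of halogens, and a benzyl group carrying a single fluorine or a single bromine would tell these apart. Also open, from the compounds shown here alone, is how a plain benzyl group, or one bearing methoxy, would compare at this position.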